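Swapping a heteroaryl for tert-butyl on a fused core

The compounds below may be only part of what the source reports. "The series", "measured", "known", "first", "only" and "open" are said of these compounds alone.

Measured compounds:
compound 1, `COc1ccc(-c2nn3cc(Cl)ccc3c2Cc2cccc(C(=O)O)n2)cc1`, 5400 nM
compound 2, `O=C(O)c1cccc(Cc2c(-c3cccs3)nn3cc(Cl)ccc23)n1`, 1100 nM
compound 3, `O=C(O)c1cccc(Cc2c(-c3ccco3)nn3cc(Cl)ccc23)n1`, 1200 nM

The three compounds share one core and differ only in the group on an aromatic carbon of the five-membered ring with two nitrogen atoms. In a functional assay on cells for antagonist activity at prostaglandin E2 receptor EP1 subtype (Rattus norvegicus), read by fluorescence and calcium flux, with a stated time of 60 s (a lower number here means a stronger inhibitor, a higher number a weaker inhibitor), compound 3 stands second highest of the three numbers, close to compound 2 and well apart from compound 1. The step of a 4.5-fold lower number from compound 1 to compound 3 (0.65 log units; beyond the scatter) and the step of a 4.9-fold lower number from compound 1 to compound 2 (0.69 log units; beyond the scatter) both show that a smaller five-membered aromatic ring in place of 4-methoxyphenyl gives a lower number, while a 1.1-fold higher number from compound 2 to compound 3 (0.04 log units; within the scatter) shows furan-2-yl and thiophen-2-yl as indistinguishable.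

Compound 4, `CC(C)(C)c1nn2cc(Cl)ccc2c1Cc1cccc(C(=O)O)n1`, carries the change (tert-butyl in place of furan-2-yl on an aromatic carbon). For the measured compounds named here, no measured step replaces an aromatic ring at this position with a group that has no ring at all, so the two steps from compound 1 offer only indirect guidance. The loss of the aromatic ring is expected to raise the number in this assay, giving an expected step of a 3.3-fold higher number from compound 3 to compound 4 (0.52 log units; beyond the scatter), though the uncertainty is large. The estimate for compound 4 is therefore 4000 nM, within a range from 1000 nM to 15000 nM.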

Compound 4, half-maximal inhibitory concentration: 48 nM
Compound 4: middle estimate off by 83-fold (1.92 log units), on the high side; measured number outside the range, below it.
By their numbers in this assay, from the lowest: compound 4; then compounds 2 and 3 (each within the scatter of the next); then compound 1.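

In this assay this position on the five-membered aromatic ring with 2 nitrogen does not need an aromatic ring at all: tert-butyl, which has no ring, brings a 25-fold lower number from compound 3 to compound 4 (1.40 log units; beyond the scatter) in place of furan-2-yl and a 23-fold lower number from compound 2 to compound 4 (1.36 log units; beyond the scatter) in place of thiophen-2-yl. It also brings a 110-fold lower number from compound 1 to compound 4 (2.05 log units; beyond the scatter) in place of 4-methoxyphenyl, so the earlier swaps among aromatic rings, modest or within the scatter, had not revealed how far the number could fall at this position. Nothing measured here explains why this change has so large an effect.

The compounds shown leave open whether isopropyl or methyl would also give a low number at this position. They also leave open how a saturated ring such as cyclohexyl or cyclopropyl would compare with tert-butyl.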